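Swapping a ring nitrogen for sulfur on the amide cap

This account rests on a few compounds, and the source may have more. Where it says the series, first, only, none or still open, it means among the compounds named here.

Compound 1 `CN1[C@@H]2c3[nH]c4ccccc4c3C[C@H]1[C@H](C#N)N1[C@@H](CNC(=O)c3cccc4c3CCCC4)c3[nH]c4ccccc4c3C[C@@H]21`: 3340 nM
Compound 2 `CN1[C@@H]2c3[nH]c4ccccc4c3C[C@H]1[C@H](C#N)N1[C@@H](CNC(=O)c3ccc4ccccc4n3)c3[nH]c4ccccc4c3C[C@@H]21`: 150 nM

In a functional assay on HT-29 cells (Homo sapiens) for cytotoxicity, read by MTT assay, with a stated time of 72 h (a lower number here means a stronger inhibitor, a higher number a weaker inhibitor), compound 2 stands lowest of the two measured numbers; its nearest neighbour, compound 1, lies a large step away, a 22-fold lower number from compound 1 to compound 2 (1.35 log units; beyond the scatter). Compound 3 `CN1[C@@H]2c3[nH]c4ccccc4c3C[C@H]1[C@H](C#N)N1[C@@H](CNC(=O)c3cc4ccccc4s3)c3[nH]c4ccccc4c3C[C@@H]21` has not yet been measured. It differs from compound 2 in one place: 1-benzothiophen-2-yl in place of quinolin-2-yl on a carbonyl carbon. Among the compounds with values here, only one measured step bears on this change, and only loosely: the replacement of 1,2,3,4-tetrahydronaphthalen-5-yl by quinolin-2-yl gave a 22-fold lower number from compound 1 to compound 2 (1.35 log units; beyond the scatter). The entering 1-benzothiophen-2-yl shares two aromatic rings with quinolin-2-yl but carries sulfur where quinolin-2-yl carries nitrogen, so some of that gain may be given back. The expected step is a 4.0-fold higher number from compound 2 to compound 3 (0.60 log units; beyond the scatter), a rise beyond the scatter but far short of compound 1. Compound 3 is therefore estimated at 600 nM in this assay, within a range from 150 nM to 2500 nM.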

Compound 3, half-maximal inhibitory concentration: 640 nM
The estimate for compound 3 lay 1.1-fold (0.03 log units) below the measured number; the range from low to high includes it.
By their numbers in this assay, from the lowest: compound 2; then compound 3; then compound 1.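

In this assay, the change of cap on the carbonyl carbon from quinolin-2-yl to 1-benzothiophen-2-yl gives a 4.3-fold higher number from compound 2 to compound 3 (0.63 log units; beyond the scatter), so this position distinguishes between two caps that both have two aromatic rings. Even so, compound 3 keeps part of the earlier gain, with a 5.2-fold lower number from compound 1 to compound 3 (0.72 log units; beyond the scatter), which shows that a cap without the quinoline ring nitrogen can still beat 1,2,3,4-tetrahydronaphthalen-5-yl. Nothing presented here explains this order of the three caps.

As far as these compounds go, this step changes the hetero atom and the size of one ring together, so the share of each remains unknown. Also open, from the compounds shown here alone, is where a naphthalen-2-yl cap, with carbon alone in both rings, or a benzofuran-2-yl cap, with oxygen in place of the sulfur, would fall in this order.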